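The source may report more compounds than this note shows. Statements on the series, on what has been measured and on what is new or still open speak of the compounds shown alone.

Three compounds have so far been measured in an assay on isolated protein for inhibition of Fatty-acid amide hydrolase 1 (Homo sapiens); a higher number here means a weaker inhibitor, a lower number a stronger inhibitor:

compound 1 `CCCCCCCC/C=C\CCCCCCC(=O)c1ncc(-c2ccccc2)o1`: 320 nM
compound 2 `CCCCCCCC/C=C\CCCCCCC(=O)c1nnc(-c2ccccn2)o1`: 3000 nM
compound 3 `CCCCCCCCCCCCCCCCCC(=O)C(F)(F)F`: 240 nM

Compound 1 sits in the middle of these three numbers. Its value and that of compound 3 lie within the usual scatter of each other, so the two cannot be told apart on these data. Compound 2, by contrast, gives a number beyond the scatter higher than compound 1, so compound 1 is the stronger inhibitor of that pair.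

Compound 4 `CCCCCCCC/C=C\CCCCCCC(=O)c1ncc(-c2ccoc2)o1` is not yet measured. It differs from compound 1 in one place only: furan-3-yl in place of phenyl on an aromatic carbon. The long chain and the carbonyl attached to the shared core are unchanged; only the group on the aromatic carbon of the core is exchanged, one aromatic ring for another of similar size.

Going by the values given here, no measured pair shows such an exchange, so there is no step to lean on. The expected step from compound 1 to compound 4 in this assay is a 1.4-fold higher number from compound 1 to compound 4 (0.15 log units; within the scatter), small and likely within the scatter, if anything toward a higher number. Compound 4 is therefore estimated at 450 nM, with a range from 150 nM to 1500 nM.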

Compound 4, inhibition constant: 610 nM
For compound 4 the middle estimate is 1.4-fold (0.13 log units) below the measured one, and the stated range covers the measured number.
By their numbers in this assay, from the lowest: compounds 3, 1 and 4 (each within the scatter of the next, the first and the last beyond it); then compound 2.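

At the aromatic carbon next to the ring oxygen, furan-3-yl in place of phenyl gives a 1.9-fold higher number from compound 1 to compound 4 (0.28 log units; within the scatter) in this assay, so the two compounds cannot be told apart. Going by these compounds alone, this is the first measured exchange at this position, and it shows that a six-membered aromatic ring of carbon only can be replaced by a five-membered aromatic ring with one oxygen, which adds a hydrogen-bond acceptor, without a step beyond the scatter. No measurement is available to explain this result.

As far as these compounds go, whether a thiophene ring, a carboxylic acid or a simple methyl group at this same place would also stay within the scatter of compound 1 remains open. Also open, from the compounds shown here alone, is whether furan-3-yl would give a similar step on the core of compound 2.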